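This account rests on a few compounds, and the source may have more. Where it says the series, first, only, none or still open, it means among the compounds named here.

Of the compounds shown here, three built on one shared core have been tested in a functional assay on MCF7 cells (Homo sapiens) for cytotoxicity, read by MTT assay, with a stated time of 96 h; a lower number here means a stronger inhibitor, a higher number a weaker inhibitor. Compound 1, `COc1cc(C(=O)c2cn(-c3ccc(C)cc3)cc2-c2ccccc2Cl)cc(OC)c1OC`, gives 180 nM. Compound 2, `COc1cc(C(=O)c2cn(-c3ccc(C)cc3)cc2-c2ccccc2[N+](=O)[O-])cc(OC)c1OC`, carries nitro in place of chloro on an aromatic carbon and gives 65 nM. That single change made a 2.8-fold lower number from compound 1 to compound 2 (0.44 log units; beyond the scatter). Compound 3, `COc1cc(C(=O)c2cn(-c3ccc(N)cc3)cc2-c2ccccc2Cl)cc(OC)c1OC`, carries amino in place of methyl on an aromatic carbon and gives 83 nM. That change made a 2.2-fold lower number from compound 1 to compound 3 (0.34 log units; beyond the scatter). The values of compound 2 and compound 3 lie within the scatter of each other, so no order between them can be read.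

Compound 4, `COc1cc(C(=O)c2cn(-c3ccc(N)cc3)cc2-c2ccccc2[N+](=O)[O-])cc(OC)c1OC`, has not yet been measured. It differs from compound 3 by nitro in place of chloro on an aromatic carbon. This is the same change that separates compound 2 from compound 1, made at the same place, while the two cores differ by amino in place of methyl on an aromatic carbon. For the measured compounds named here, only one earlier example of the change exists, so whether it carries over onto the core of compound 3 is open. Because the earlier step was a 2.8-fold lower number from compound 1 to compound 2 (0.44 log units; beyond the scatter), the step from compound 3 to compound 4 in this assay is expected to be a 2.4-fold lower number from compound 3 to compound 4 (0.38 log units; beyond the scatter). Compound 4 is therefore estimated at 35 nM, with a range from 15 nM to 90 nM.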

Compound 4, half-maximal inhibitory concentration: 53 nM
The estimate for compound 4 lay 1.5-fold (0.18 log units) below the measured number, within the range that was stated.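

Putting nitro in place of chloro on the core of compound 3 gave a 1.6-fold lower number from compound 3 to compound 4 (0.19 log units; within the scatter), and in this assay this step does not differ measurably from the earlier one: the same change on two cores in this assay, a 2.8-fold lower number (0.44 log units; beyond the scatter) from compound 1 to compound 2 and a 1.6-fold lower number (0.19 log units; within the scatter) from compound 3 to compound 4, 1.8-fold (0.25 log units) apart, within the scatter of two such steps. Putting amino in place of methyl on the core of compound 2 gave a 1.2-fold lower number from compound 2 to compound 4 (0.09 log units; within the scatter), and this step also stands level with its earlier counterpart: the same change on two cores in this assay, a 2.2-fold lower number (0.34 log units; beyond the scatter) from compound 1 to compound 3 and a 1.2-fold lower number (0.09 log units; within the scatter) from compound 2 to compound 4, 1.8-fold (0.25 log units) apart, within the scatter of two such steps. Each change is therefore consistent with carrying over from one core to the other, but both new steps lie within the scatter on their own, so neither shows a real shift on its new core, and a single pair of steps for each change cannot establish a general rule for the series.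

The compounds shown leave open how other groups would behave at these two places, such as a nitrile or a trifluoromethyl group in place of chloro, or a hydroxyl or a dimethylamino group in place of amino. They also leave open whether either change would carry over onto a different core.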